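A few compounds are considered here, and "the series" means these few. Any claim that something is new, unique, unknown or untested is made for them only; others in the source may bear on it.

Among the measured compounds shown here, compound 3 (`CC1CCN(c2c(S(=O)(=O)c3ccc(F)c(Cl)c3)cnc3ccc(F)cc23)CC1`) gives the highest of the three numbers so far in an assay on isolated protein for displacement of a labelled ligand from metabotropic glutamate receptor 5 (Homo sapiens), with a stated time of 60 min, tested at 1 uM (a lower number here means less inhibition, a higher number more inhibition at the concentration tested (going by the name of the read-out)), where compound 3 gives 95%. Compound 1 (`CC1CCN(c2c(S(=O)(=O)c3ccccc3)cnc3ccccc23)CC1`) stands nearest, and in this assay compound 1 gives 89.2%, within the scatter of compound 3. Compound 2 (`CC1CCN(c2c(S(=O)(=O)c3ccc(F)cc3)cnc3ccc(F)cc23)CC1`) stands furthest, and in this assay compound 2 gives 87%, also within the scatter of compound 3.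

Compound 4 (`CC1CCN(c2c(S(=O)(=O)c3ccccc3)cnc3ccc(F)cc23)CC1`) is the next compound, not yet measured. It differs from compound 3 in this way: phenyl in place of 3-chloro-4-fluorophenyl on a sulfonyl sulfur.

For the measured compounds named here, one measured step bears on this change, since it also concerns a substituent on the ring attached to the sulfonyl sulfur: a number 8 percentage points higher from compound 2 to compound 3 (within the scatter). That step was within the scatter, so removing the chloro again would be expected to move the number by a similarly small amount. Compounds 1 and 2 both carry a phenyl or a fluorophenyl on the sulfonyl sulfur and show values within the scatter of each other.

Compound 4 is therefore expected to show a number 7 percentage points lower from compound 3 to compound 4 (within the scatter) in this assay, a step not beyond the scatter. The estimate for compound 4 is 88%, with a range from 78% to 96%.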

Compound 4, a percentage reported as inhibition, at one concentration (the size of the read-out at that concentration, not a potency): 40%
For compound 4 the middle estimate is 48 percentage points above the measured one; the whole stated range lies above it.
By their numbers in this assay, from the lowest: compound 4; then compounds 2, 1 and 3 (each within the scatter of the next).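

In this assay, among the compounds shown here, the result shows that the substituents on the ring attached to the sulfonyl sulfur matter far more than the earlier compounds suggested: phenyl in place of 3-chloro-4-fluorophenyl gives a number 55 percentage points lower from compound 3 to compound 4 (beyond the scatter) at this position. The chloro is not needed to keep the number high, since the loss of the fluoro alone accounts for a drop of similar size, with a number 47 percentage points lower from compound 2 to compound 4 (beyond the scatter) for hydrogen in place of fluoro on an aromatic carbon. Phenyl on the sulfonyl sulfur is not poor in itself, however: compound 1 carries it too, and a number 49.2 percentage points lower from compound 1 to compound 4 (beyond the scatter) comes with the gain of a single fluoro, so the effect of one fluoro depends on the presence of the other within this small set.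

No evidence at hand says why these steps are so large. Going by these compounds, whether a methoxy group or a nitrile on that ring could stand in for the fluoro, and whether a pyridine could replace the phenyl, stays open, as does how these percentages at a single concentration relate to potency.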